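The compounds below may be only part of what the source reports. "The series", "measured", "known", "first", "only" and "open" are said of these compounds alone.

Measured compounds in a functional assay on HepG2 cells (Homo sapiens) for cytotoxicity, read by MTT assay, with a stated time of 72 h; on this read-out lower numbers stand for stronger inhibition and higher numbers for weaker inhibition:
- compound 1 `CNC(=O)c1cc(Oc2ccc(NC(=O)c3nn(-c4ccccc4C(F)(F)F)c(=O)cc3C)cc2F)ccn1`: > 40000 nM, a limit of the assay
- compound 2 `CNC(=O)c1cc(Oc2ccc(NC(=O)c3nn(-c4ccccc4OC(F)(F)F)c(=O)cc3C)cc2F)ccn1`: > 40000 nM, a limit of the assay
- compound 3 `CNC(=O)c1cc(Oc2ccc(NC(=O)c3nn(-c4ccccc4F)c(=O)cc3C)cc2F)ccn1`: > 40000 nM, a limit of the assay

Compound 1 stands only at a limit in this assay, with no number to place it. The same holds for the other two, as the limit of > 40000 nM in this assay, at which 3 of the 3 values shown sit, shows. The measured steps a step that the two limits leave unreadable from compound 1 to compound 2, a step that the two limits leave unreadable from compound 1 to compound 3 and a step that the two limits leave unreadable from compound 2 to compound 3 each vary the group on the aromatic carbon of the phenyl on the core of compound 1, and none gives a readable size.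

Compound 4 `Cc1cc(=O)n(-c2ccccc2C(F)(F)F)nc1C(=O)Nc1ccc(Oc2ncnc3sccc23)c(F)c1` differs from compound 1 elsewhere: a group of 9 heavy atoms (6 carbon, 2 nitrogen, 1 sulfur; one five-membered aromatic ring with 1 hetero atom, one six-membered aromatic ring with 2 hetero atoms) in place of a group of 10 heavy atoms (7 carbon, 2 nitrogen, 1 oxygen; one six-membered aromatic ring with 1 hetero atom), on an oxygen on an aromatic ring. Among the measured compounds shown here, no measured step touches the ether-linked group, so no step bears directly on this change; the measured series gives no readable movement at all.

The expectation for compound 4 therefore rests only on the limits seen so far: compound 4 is estimated at 40000 nM, within 8000 nM to 100000 nM, most likely again reported as a limit. The step from compound 1 to compound 4 is expected to be a number no higher from compound 1 to compound 4 (the limit leaves the size open), i.e. none readable beyond the scatter.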

Compound 4, half-maximal inhibitory concentration: 14700 nM
The estimate for compound 4 lay 2.7-fold (0.43 log units) above the measured number; low and high end bracket the measured number.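

Replacing 2-(methylcarbamoyl)pyridin-4-yl on the oxygen with the group of compound 4, which carries a five-membered and a six-membered aromatic ring, gives in this assay an at least 2.7-fold lower number from compound 1 to compound 4 (0.43 log units; beyond the scatter). Among the compounds shown here, the three variations of the group on the phenyl gave no readable step, so this change to the ether-linked group is the first to yield a measured number rather than a limit. The true size of the step stays open because compound 1 sits at a limit, as do two other compounds: the limit of > 40000 nM in this assay, at which 3 of the 4 values shown sit.

Only one replacement on this oxygen is shown, so the data cannot separate the loss of the methylcarbamoyl group from the entry of the new ring pair. Also open, on these data alone, is whether a pyridine bearing an amine or a carboxylic acid would give a measured number, and whether trifluoromethoxy or fluoro on the phenyl would do so alongside the new group.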